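Methylation of the phenolic oxygen in a quinolinyl urea series

A few compounds are considered here, and "the series" means these few. Any claim that something is new, unique, unknown or untested is made for them only; others in the source may bear on it.

Two compounds of the series have been run in an ADME assay for permeability, using PAMPA, at pH 7.4; on this read-out lower numbers stand for lower permeability and higher numbers for higher permeability. Compound 1 `COc1ccc(NC(=O)Nc2cc(C)nc3ccccc23)cc1Cl` gives 336 10^-6 cm/s in this assay, while compound 2 `Cc1cc(NC(=O)Nc2ccc(O)cc2)c2ccccc2n1` gives 3 10^-6 cm/s in this assay. Compound 2 thus stands at the lowest of the two numbers; the nearest number is that of compound 1, and the gap between them lies well beyond the usual scatter. Compound 3 `COc1ccc(NC(=O)Nc2cc(C)nc3ccccc23)cc1` has not yet been measured in this assay. Compound 3 differs from compound 2 by methyl in place of hydrogen on an oxygen on an aromatic ring, so that the hydroxy of compound 2 becomes a methoxy. For the measured compounds named here, no step between two measured compounds isolates this change, so the expectation rests on what the two numbers show. Compound 3 is expected to sit far above compound 2 and close to compound 1, because compound 1, which carries the same methoxy, gives 336 10^-6 cm/s in this assay. The step from compound 2 to compound 3 is therefore expected to be a large rise, a 67-fold higher number from compound 2 to compound 3 (1.82 log units; beyond the scatter), well beyond the scatter. For compound 3 the estimate in this assay is 200 10^-6 cm/s, with a range from 60 10^-6 cm/s to 450 10^-6 cm/s.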

Compound 3, apparent permeability: 787 10^-6 cm/s
Compound 3: middle estimate off by 3.9-fold (0.59 log units), on the low side; the measured number lies above the stated range.
By their numbers in this assay, from the lowest: compound 2; then compound 1; then compound 3.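

Notes on the oxygen position: in this assay, the change from hydroxy to methoxy can now be read on its own, with methyl in place of hydrogen on an oxygen on an aromatic ring giving a 260-fold higher number from compound 2 to compound 3 (2.42 log units; beyond the scatter), a large step beyond the scatter. The second single-place comparison keeps the methoxy and puts hydrogen in place of chloro on an aromatic carbon, giving a 2.3-fold higher number from compound 1 to compound 3 (0.37 log units; beyond the scatter), a modest step that is also beyond the scatter, so the high numbers in this pair do not depend on the chloro. Nothing available gives a reason for either step.

The compounds shown leave open whether the large step belongs to methyl specifically or would also appear with an ethoxy, a longer chain on the same oxygen, or an amine in place of the hydroxy. They also leave open whether the chloro step seen with the methoxy would keep its direction and size on a compound that retains the hydroxy.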